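Replacing a Benzyl Amide with a Hydroxyindanyl Amine

This account rests on a few compounds, and the source may have more. Where it says the series, first, only, none or still open, it means among the compounds named here.

Of the compounds shown here, three sharing one core have been measured in an assay on CHO cells for displacement of a labelled ligand from 5-hydroxytryptamine receptor 1D (Homo sapiens); on this read-out lower numbers stand for stronger inhibition and higher numbers for weaker inhibition. Compound 1 `COC[C@H](NC1CCN(CCCc2c[nH]c3ccc(Cn4cncn4)cc23)CC1)c1ccc(F)cc1` gives 5 nM. Compound 2 `CC(=O)Nc1ccc(CNC2CCN(CCCc3c[nH]c4ccc(-n5cnnc5)cc34)CC2)cc1` gives 3 nM, the second highest of the three numbers; its gap to compound 1 lies within the scatter, whereas compound 3 `CC(=O)Nc1ccc([C@H](C)NCC2CCN(CCCc3c[nH]c4ccc(-n5cnnc5)cc34)CC2)cc1` gives 0.6 nM, a gap that lies beyond it. Compound 4 `O[C@@H]1Cc2ccccc2[C@H]1NC1CCN(CCCc2c[nH]c3ccc(-n4cnnc4)cc23)CC1` has not yet been measured. It differs from compound 2 in one place: 2-hydroxy-2,3-dihydro-1H-inden-1-yl in place of 4-acetamidobenzyl on an amine nitrogen. Going by the values given here, no step between measured compounds mirrors this exchange, so the expectation rests on compound 2 alone, because compound 2 gives 3 nM. The expected step is a 1.7-fold higher number from compound 2 to compound 4 (0.22 log units; within the scatter), within the scatter. Compound 4 is estimated at 5 nM, with a range from 1.5 nM to 20 nM.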

Compound 4, half-maximal inhibitory concentration: 6.6 nM
For compound 4 the middle estimate is 1.3-fold (0.12 log units) below the measured one; the range from low to high includes it.
By their numbers in this assay, from the lowest: compound 3; then compounds 2, 1 and 4 (each within the scatter of the next, the first and the last beyond it).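

In this assay the amine nitrogen accepts a very different group: 2-hydroxy-2,3-dihydro-1H-inden-1-yl in place of 4-acetamidobenzyl gives a 2.2-fold higher number from compound 2 to compound 4 (0.34 log units; beyond the scatter) as a modest step. A five-membered non-aromatic ring with 2 defined stereocentres therefore costs little here, even though the acetamide is gone. Nothing available explains this step.

On these data alone, whether the hydroxyl group or its stereochemistry contributes to the binding of compound 4 remains open. A methoxy or amino group in its place would help test this.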